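Oxazolidinone side chain: imidazolyl swapped for methyl carbamate

A few compounds are considered here, and "the series" means these few. Any claim that something is new, unique, unknown or untested is made for them only; others in the source may bear on it.

Working notes on the series. The shared core is held constant; variation is on a saturated chain carbon bound to a saturated ring carbon. Compound 1 `O=C1O[C@@H](CO)CN1c1ccc(-n2cc(-c3ccccn3)cn2)c(F)c1` gives 1.67 in a physicochemical assay for lipophilicity, read by HPLC, measured as octanol-water partition; on this read-out higher numbers stand for higher lipophilicity and lower numbers for lower lipophilicity. Compound 2 `COC[C@H]1CN(c2ccc(-n3cc(-c4ccccn4)cn3)c(F)c2)C(=O)O1` gives 2.18, a step of a number 0.51 log units higher from compound 1 to compound 2 (beyond the scatter). Compound 3 `O=C1O[C@@H](Cn2ccnc2)CN1c1ccc(-n2cc(-c3ccccn3)cn2)c(F)c1` gives 1.73, which stands second highest of the three numbers, nearest compound 1 (a number 0.06 log units higher from compound 1 to compound 3 (within the scatter)) and furthest from compound 2 (a number 0.45 log units lower from compound 2 to compound 3 (beyond the scatter)).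

Compound 4 `COC(=O)NC[C@H]1CN(c2ccc(-n3cc(-c4ccccn4)cn3)c(F)c2)C(=O)O1` differs from compound 3 by (methoxycarbonyl)amino in place of 1H-imidazol-1-yl on a saturated chain carbon bound to a saturated ring carbon. Going by the values given here, no measured step covers this exact exchange. The two steps that reach compound 3 show that the group at this position has moved this assay by no more than a modest amount, with the hydroxy and imidazolyl forms within the scatter of each other and the methoxy form modestly higher. The carbamate of compound 4 is therefore expected to land within the scatter of compound 3, with the estimated step of a number 0.02 log units higher from compound 3 to compound 4 (within the scatter) neither clearly up nor down. For compound 4 the estimate is 1.75, with a range from 1.35 to 2.15.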

Compound 4, partition coefficient: 2.03
Estimate against measurement, compound 4: 0.28 log units below; the range from low to high includes it.
By their numbers in this assay, from the lowest: compounds 1, 3, 4 and 2 (each within the scatter of the next, the first and the last beyond it).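

In this assay, (methoxycarbonyl)amino in place of 1H-imidazol-1-yl gives a number 0.30 log units higher from compound 3 to compound 4 (within the scatter), and in place of methoxy it gives a number 0.15 log units lower from compound 2 to compound 4 (within the scatter), so compound 4 cannot be separated from either compound. In place of hydroxy it gives a number 0.36 log units higher from compound 1 to compound 4 (beyond the scatter), which means that the hydroxy and 1H-imidazol-1-yl forms, inseparable from each other, do not relate to this new group in the same way, and the four groups at this place do not fall into distinct sets. Going by these compounds alone, nothing measured so far accounts for these steps.

From the compounds shown here alone, whether an amine or a carboxylic acid at this place, or a longer chain carrying the (methoxycarbonyl)amino group, would stay within the spread of these four compounds remains open. Also open, going by these compounds, is whether a methyl group in place of the carbamate hydrogen would shift the read-out.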